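The source may hold more compounds than are shown below. What is called first, only, known or untested is meant among the compounds shown, and "the series" means these compounds.

Measured compounds, in an assay for inhibition of Indoleamine 2,3-dioxygenase 1 (Homo sapiens), with stated times of 10 min and 60 min; a lower number here means a stronger inhibitor, a higher number a weaker inhibitor:
- compound 1 `Oc1ccc(CNc2cc(C(F)(F)F)cc3[nH]ncc23)cc1` gives 36700 nM
- compound 2 `FC(F)(F)c1cc(NCc2cccc3sccc23)c2cn[nH]c2c1` gives > 100000 nM, a limit of the assay and not a number
- compound 3 `Cc1ccc(CNc2cc(C(F)(F)F)cc3[nH]ncc23)c([N+](=O)O)c1` gives > 100000 nM, likewise a limit and not a number

Where compound 3 stands: its result is a limit only, so no number is known for it in this assay. Of the three results shown, two sit at the same limit, see (the limit of > 100000 nM in this assay, at which 2 of the 3 values shown sit); only compound 1 returns a number, and that number is weak. Going by the values given here, nothing can be said about the size of any gap between compound 3 and the others, since no step between measured compounds is available.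

The next compound, compound 4 `CS(=O)(=O)c1ccc(CNc2cc(C(F)(F)F)cc3[nH]ncc23)c([N+](=O)O)c1`, differs from compound 3 in one place: methylsulfonyl in place of methyl on an aromatic carbon. Among the compounds with values here, no measured step informs this change, so no direction beyond the usual scatter is expected. Compound 4 is expected to give 120000 nM, within 30000 nM to 500000 nM, most probably again as a limit. The expected step that the limit leaves unreadable from compound 3 to compound 4 is thus none beyond the scatter.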

Compound 4, half-maximal inhibitory concentration: 58000 nM
Estimate against measurement, compound 4: 2.1-fold (0.32 log units) above; the range from low to high includes it.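

In this assay compound 4 gives 58000 nM, so at this position, on an aromatic carbon para to a large group, methylsulfonyl in place of methyl yields a result that can be read as a number, though a weak one. Compound 3 gives > 100000 nM, which is a limit of the assay and not a number. The change gives an at least 1.7-fold lower number from compound 3 to compound 4 (0.23 log units; that floor lies within the scatter), so only a floor on the step is known, and that floor does not establish a real gain for methylsulfonyl over methyl; the true size of the step stays hidden behind the ceiling of the assay: the limit of > 100000 nM in this assay, at which 2 of the 4 values shown sit.

What the compounds shown leave open is how far the true value of compound 3 lies from that ceiling, and thus whether the change from methyl to methylsulfonyl matters at all. Also open, from the compounds shown here alone, is how an amine, a carboxylic acid or a nitrile would read at the same position on the same core, and whether any group there can bring the series out of this weak range.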